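The source may report more compounds than this note shows. Statements on the series, on what has been measured and on what is new or still open speak of the compounds shown alone.

Compound 3 `Cc1cc(N2CCN(C)CC2)cn2c(CSCCc3ccccc3)cnc12` gives 20 ug/mL in an ADME assay on HEL cells (Homo sapiens) for cytotoxicity, with a stated time of 3 days (a lower number here means that less compound is tolerated, a higher number that more compound is tolerated), the lowest of the two numbers shown there. Compound 1 `Cc1cc(-c2ccc(C=O)cc2)cn2c(CSCCc3ccccc3)cnc12` gives 100 ug/mL in this assay. Compound 2 `Cc1cc(-c2ccc3[nH]ccc3c2)cn2c(CSCCc3ccccc3)cnc12` returns only a limit in this assay, >= 20 ug/mL, which is the limit of >= 20 ug/mL in this assay, at which 1 of the 3 values shown sits. Compound 4 `Cc1cc(-n2cccc2)cn2c(CSCCc3ccccc3)cnc12` differs from compound 3 by 1H-pyrrol-1-yl in place of 4-methylpiperazin-1-yl on an aromatic carbon. Among the measured compounds shown here, two measured steps bear on this change: a 5.0-fold lower number from compound 1 to compound 3 (0.70 log units; beyond the scatter) and a number no higher from compound 2 to compound 3 (the limit leaves the size open). Compound 1 and compound 2 both carry an aromatic ring in place of the 4-methylpiperazin-1-yl group, as compound 4 does, and the readable one of the two steps is modest. The expected step is therefore a 2.5-fold higher number from compound 3 to compound 4 (0.40 log units; beyond the scatter), upward. Compound 4 is expected to give 50 ug/mL, within 20 ug/mL to 100 ug/mL.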

Compound 4, minimum cytotoxic concentration: >= 4 ug/mL
Compound 4: a limit, no number; the forecaster's own chance of this, stated with the estimate: 30%; the middle value is on the limit's open side.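

Compound 4 returns only a limit in this assay, >= 4 ug/mL, so its steps from compound 1, compound 2 and compound 3 cannot be read. The compounds shown leave open whether 1H-pyrrol-1-yl in place of 4-methylpiperazin-1-yl raises or lowers the number.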